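Acetyl in Place of Methyl on the Shared Core

A few compounds are considered here, and "the series" means these few. Any claim that something is new, unique, unknown or untested is made for them only; others in the source may bear on it.

In a functional assay on MCF7 cells (Homo sapiens) for inhibition, read by radiometric assay and XTT assay (a lower number here means a stronger inhibitor, a higher number a weaker inhibitor), compound 1 `CCCCCCCC[C@@]1(C)SC(O)=C(C)C1=O` gives 48 ug/mL. Compound 2 `C=CCOC(=O)OC1=CC(=O)S[C@]1(C)CCCCCCCC` gives 37.3 ug/mL, and the two values lie within the usual scatter of each other. The reading for compound 3 `C[C@]1(Cc2ccccc2)SC(O)=CC1=O` is a limit rather than a number: > 80 ug/mL.

The step followed here leads from compound 1 to compound 4 `CCCCCCCC[C@@]1(C)SC(O)=C(C(C)=O)C1=O`, which carries acetyl in place of methyl on a double-bonded ring carbon. This carbon stands next to the ring atom that bears a hydroxy group. Among the measured compounds shown here, no pair of measured compounds differs in one place, so the data hold no direct guide to this change in this assay. The expectation therefore starts from compound 1 at 48 ug/mL, and no change beyond the scatter is expected, in either direction. The estimated step is a 1.1-fold lower number from compound 1 to compound 4 (0.06 log units; within the scatter). For compound 4 the expected value is an estimated 42 ug/mL, with an estimated range from 20 ug/mL to 80 ug/mL.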

Compound 4, half-maximal inhibitory concentration: 12.5 ug/mL
For compound 4 the middle estimate is 3.4-fold (0.53 log units) above the measured one, outside the stated range (below it).
By their numbers in this assay, from the lowest: compound 4; then compounds 2 and 1 (each within the scatter of the next). At a limit, above all of these: compound 3.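

In this assay the double-bonded ring carbon next to the ring atom that bears a hydroxy group turns out to respond to substitution: acetyl in place of methyl gives a 3.8-fold lower number from compound 1 to compound 4 (0.58 log units; beyond the scatter) as a modest step beyond the scatter. Among the compounds shown here, the earlier compounds held no pair differing in one place, so this is the first reading of what a single change on the shared core does in this assay. Nothing measured here accounts for the step.

From the compounds shown here alone, whether the added carbonyl or the larger group matters remains open, and a formyl group, a propanoyl group or a carboxylic acid on this same ring carbon would help to separate the two. Going by these compounds, it is also open whether acetyl at this carbon would lower the number with a benzyl group or a shorter chain in place of the octyl chain.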